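Swapping azetidin-3-yl for isopropyl: cytotoxicity outlook

The source may hold more compounds than are shown below. What is called first, only, known or untested is meant among the compounds shown, and "the series" means these compounds.

Compound 1 `CC1(n2c(=O)n(Cc3cc4cc(Cl)ccc4n3CCCS(C)(=O)=O)c3cnccc32)CC1`: in an ADME assay on HeLa cells (Homo sapiens) for cytotoxicity, read by ATP content, with a stated time of 3 days (on this read-out higher numbers stand for lower toxicity in this test and lower numbers for higher toxicity in this test), compound 1 gives > 50000 nM, which is a limit of the assay rather than a number.
Compound 2 `CS(=O)(=O)CCCn1c(Cn2c(=O)n(C3CNC3)c3ccncc32)cc2cc(Cl)ccc21`: in this assay compound 2 gives > 50000 nM, again a limit of the assay and not a number.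

For the measured compounds named here, compound 2 therefore stands at the upper end of what this assay can report, and the only other value shown, that of compound 1, is a limit as well. Going by the values given here, the one measured step, a step that the two limits leave unreadable from compound 1 to compound 2, cannot be sized, since both of its ends sit at a limit; this is summed up by the limit of > 50000 nM in this assay, at which 2 of the 2 values shown sit.

Compound 3 `CC(C)n1c(=O)n(Cc2cc3cc(Cl)ccc3n2CCCS(C)(=O)=O)c2cnccc21` differs from compound 2 in one place: isopropyl in place of azetidin-3-yl on an aromatic nitrogen. The step from compound 1 to compound 2 is the only one that touches the same ring nitrogen, and its size is unreadable, so no direction can be taken from it. The expectation is simply that compound 3, like both measured compounds, remains at the assay limit, so that the step that the limit leaves unreadable from compound 2 to compound 3 is expected to be nothing beyond the scatter. Compound 3 is thus estimated at 60000 nM, within a range from 30000 nM to 150000 nM.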

Compound 3, half-maximal cytotoxic concentration: > 50000 nM
Compound 3: a limit, no number; the forecaster's own chance of this, stated with the estimate: 85%; the middle value lies beyond the limit too.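

Compound 3 also sits at a limit of the assay, so no new step can be read among compound 1, compound 2 and compound 3, for the reason summed up here: the limit of > 50000 nM in this assay, at which 3 of the 3 values shown sit.

The compounds shown leave open whether azetidin-3-yl, isopropyl and 1-methylcyclopropyl on this aromatic nitrogen differ at all in this assay since none of them has a number yet.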